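The source may hold more compounds than are shown below. What is called first, only, known or untested is meant among the compounds shown, and "the series" means these compounds.

Measured in a functional assay on HCT-116 cells (Homo sapiens) for inhibition, read by CCK-8 assay, with a stated time of 48 h; on this read-out lower numbers stand for stronger inhibition and higher numbers for weaker inhibition:
Compound 1 `COc1cc(-c2ccnc3cc(-c4ccc(Cl)cc4)nn23)cc(OC)c1OC`: 3340 nM
Compound 2 `COc1cc(-c2cc3nccc(-c4c[nH]c5ccccc45)n3n2)cc(OC)c1OC`: > 10000 nM, a limit of the assay
Compound 3 `Cc1ccc(-c2cc3nccc(-c4ccc(F)cc4)n3n2)cc1`: > 10000 nM, a limit of the assay

Compound 1 is the only one of the three with a real number in this assay. Compound 2 stands at a limit of the assay. Compound 3 also stands at a limit of the assay, so that two of the three results sit at the limit of > 10000 nM in this assay, at which 2 of the 3 values shown sit. Compound 4 `COc1cc(-c2ccnc3cc(-c4cccc(C#N)c4)nn23)cc(OC)c1OC` has not yet been measured. It differs from compound 1 in one place: 3-cyanophenyl in place of 4-chlorophenyl on an aromatic carbon. Within the data shown here, no pair of measured compounds shows this kind of exchange, so its size and direction are unknown here. In this assay the step from compound 1 to compound 4 is expected to be small, likely within the scatter of repeated measurement, as a 1.3-fold higher number from compound 1 to compound 4 (0.13 log units; within the scatter). Compound 4 is therefore expected to give about 4500 nM, estimated between 1500 nM and 15000 nM.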

Compound 4, half-maximal inhibitory concentration: > 10000 nM
Compound 4 was reported as a limit (the forecaster's own chance of this, stated with the estimate: 30%); at least 2.2-fold (0.34 log units) between middle value and limit.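

In this assay, the exchange of 4-chlorophenyl for 3-cyanophenyl gives an at least 2.9-fold higher number from compound 1 to compound 4 (0.47 log units; beyond the scatter). Among these compounds, this is the first sign that the aromatic group at this position cannot be swapped freely on the core of compound 1. Compound 4 gives > 10000 nM, a limit of the assay, as do most compounds in this small set: the limit of > 10000 nM in this assay, at which 3 of the 4 values shown sit.

Among the compounds shown here, the single exchange does not separate the loss of the chlorine from the arrival of the nitrile or from the change in where the substituent sits on the phenyl ring. On these data alone, how a plain phenyl or a pyridyl group would behave in this place also stays open.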